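This account rests on a few compounds, and the source may have more. Where it says the series, first, only, none or still open, it means among the compounds named here.

Measured in a functional assay on TK-10 cells (Homo sapiens) for cytotoxicity, read by sulforhodamine B assay, with a stated time of 48 h; on this read-out lower numbers stand for stronger inhibition of growth and higher numbers for weaker inhibition of growth:

compound 1, `Nc1nc(Cl)c2ncn(Cc3ccc(CCl)cc3)c2n1`: compound 1 gives 40700 nM
compound 2, `ClCc1cccc(Cn2cnc3c(Cl)nc(Cl)nc32)c1`: compound 2 gives 3980 nM
compound 3, `ClCc1ccc(Cn2cnc3c(Cl)nc(Cl)nc32)cc1`: compound 3 gives 20400 nM

Compound 2 holds the lowest of the three numbers. Compound 3 stands nearest to it, and compound 1 furthest, and both of those gaps lie beyond the scatter. Compound 2 and compound 3 are built from the same atoms joined differently; how the two cores differ is not broken down here.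

Compound 3 and compound 1 differ in one place: amino in place of chloro on an aromatic carbon. That change gave a 2.0-fold higher number from compound 3 to compound 1 (0.30 log units; within the scatter), a step that stays within the scatter of the assay.

The unmeasured compound 4, `Nc1nc(Cl)c2ncn(Cc3cccc(CCl)c3)c2n1`, relates to compound 2 in the same way: amino in place of chloro on an aromatic carbon. The surroundings of the changed carbon read the same in both pairs, so this is the same change, seen twice among these compounds.

For compound 4 the expected step is a 2.0-fold higher number from compound 2 to compound 4 (0.30 log units; within the scatter). Going by the values given here, this expectation rests on the one measured instance of the change, because a 2.0-fold higher number from compound 3 to compound 1 (0.30 log units; within the scatter) was small and within the scatter, and because compound 2 starts from 3980 nM. Among the compounds with values here, with only a single measured instance of this change, the range is kept wide. Compound 4 is expected to give about 8000 nM in this assay, plausibly between 3000 nM and 20000 nM.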

Compound 4, concentration for total growth inhibition: 7080 nM
Compound 4: the middle estimate sits 1.1-fold (0.05 log units) above what was measured; the measured number falls inside the stated range.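

In this assay, amino in place of chloro on an aromatic carbon gave a 1.8-fold higher number from compound 2 to compound 4 (0.25 log units; within the scatter), and this step can be set directly beside the earlier one on the other core: the same change on two cores in this assay, a 2.0-fold higher number (0.30 log units; within the scatter) from compound 3 to compound 1 and a 1.8-fold higher number (0.25 log units; within the scatter) from compound 2 to compound 4, 1.1-fold (0.05 log units) apart, within the scatter of two such steps

In these two pairs, then, the change carried from one core to the other with no detectable difference in size, and on each core the amino and chloro compounds cannot be told apart on this read-out. Going by these compounds alone, this does not show that the change is without effect in general, as it rests on only two pairs, whose cores are built from the same atoms joined differently, in a single cell assay, and it gives no reason why the step stays so small.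

All four compounds shown carry either chloro or amino on this aromatic carbon, so it remains open how a methoxy group, a methylamine or a longer chain would behave there. All four also keep the chloromethyl group, which leaves open what a plain methyl or a hydroxymethyl group in its place would do to the number, and whether the amino-for-chloro step would hold up on such compounds.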